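Methoxymethoxy in place of diisopropylamino: compound 3 to compound 4

This account rests on a few compounds, and the source may have more. Where it says the series, first, only, none or still open, it means among the compounds named here.

Going by the values given here, in a functional assay on MCF7 cells (Homo sapiens) for antiproliferative activity, read by MTT assay, with a stated time of 48 h (a higher number here means a weaker inhibitor, a lower number a stronger inhibitor), compound 3 (`CC(C)=CCC[C@]1(C)/C=C/[C@@H](OC(=O)C=C(C)C)[C@](C)(O)/C=C/C(=O)/C(CN(C(C)C)C(C)C)=C\C1`) gives 780 nM, the middle of the three numbers so far. Compound 1 (`CC(C)=CCC[C@]1(C)/C=C/[C@@H](OC(=O)C=C(C)C)[C@](C)(O)/C=C/C(=O)/C(CF)=C\C1`) gives 240 nM. Compound 2 (`CC(C)=CCC[C@]1(C)/C=C/[C@@H](OC(=O)C=C(C)C)[C@](C)(O)/C=C/C(=O)/C(C(=O)O)=C\C1`) gives 16100 nM.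

Compound 4 (`COCOC/C1=C/C[C@](C)(CCC=C(C)C)/C=C/[C@@H](OC(=O)C=C(C)C)[C@](C)(O)/C=C/C1=O`) has methoxymethoxy in place of diisopropylamino on a saturated chain carbon bound to a double-bonded ring carbon.

Among the compounds with values here, the closest precedent is a 3.3-fold higher number from compound 1 to compound 3 (0.51 log units; beyond the scatter), a modest step that exchanges groups at this same place. The two large steps, a 67-fold higher number from compound 1 to compound 2 (1.83 log units; beyond the scatter) and a 21-fold lower number from compound 2 to compound 3 (1.31 log units; beyond the scatter), both involve the carboxy group of compound 2, which is absent from compound 4. They therefore bear on this change only weakly. The new group keeps the saturated chain carbon found in the two more active compounds, so only a small move towards compound 1 is expected in this assay, possibly none beyond the scatter. The expected step is a 1.6-fold lower number from compound 3 to compound 4 (0.19 log units; within the scatter). For compound 4 the estimate is 500 nM, with an expected range of 170 nM to 1800 nM.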

Compound 4, half-maximal inhibitory concentration: 3120 nM
Beside the measured number, compound 4's estimate is 6.2-fold (0.80 log units) below it; the whole stated range lies below it.
By their numbers in this assay, from the lowest: compound 1; then compound 3; then compound 4; then compound 2.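

In this assay, keeping a saturated chain carbon at this place does not by itself preserve the activity: a 4.0-fold higher number from compound 3 to compound 4 (0.60 log units; beyond the scatter), and a 13-fold higher number from compound 1 to compound 4 (1.11 log units; beyond the scatter). The group carried on that carbon therefore sets the number even when no carboxy is present, and fluoro, diisopropylamino and methoxymethoxy now stand in that order from the lowest number, each gap beyond the scatter. The (methoxymethoxy)methyl group still improves on the carboxy group, with a 5.2-fold lower number from compound 2 to compound 4 (0.71 log units; beyond the scatter), so compound 2 remains the highest of the series.

No measurement available here accounts for this order. As far as these compounds go, it remains open whether a hydroxy group, a methoxy group or a cyclic amine such as morpholine on this carbon would fall nearer compound 1 or compound 4.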